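The source may hold more compounds than are shown below. What is called first, only, known or untested is meant among the compounds shown, and "the series" means these compounds.

Working notes on the series. Within the data shown here, compound 1 `CC1=C(/C=C/C(C)=C/C=C/C(C)=C\C(=O)NCc2ccc(F)cc2)C(C)(C)CCC1n1ccnc1` gives 1410 nM in a functional assay on MDA-MB-231 cells (Homo sapiens) for inhibition, read by MTT assay (on this read-out lower numbers stand for stronger inhibition of growth and higher numbers for weaker inhibition of growth), and stands at the lower of the two numbers measured so far. Compound 2 `CC1=C(/C=C/C(C)=C/C=C/C(C)=C\C(=O)Nc2ccccc2)C(C)(C)CC=C1c1cccnc1` differs from compound 1 in several places. In this assay compound 2 gives 25100 nM, a far higher number. Compound 3 `CC1=C(/C=C/C(C)=C/C=C/C(C)=C\C(=O)Nc2ccc(F)cc2)C(C)(C)CCC1n1ccnc1` is not yet measured; it differs from compound 1 only by 4-fluorophenyl in place of 4-fluorobenzyl on an amide-type nitrogen. Among the measured compounds shown here, no measured pair isolates this change, so the step is expected to be small, likely a mild weakening: a 1.8-fold higher number from compound 1 to compound 3 (0.25 log units; within the scatter) is the expected step. For compound 3 the estimate in this assay is 2500 nM, with a range of 800 nM to 8000 nM.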

Compound 3, concentration for 50% growth inhibition: 4950 nM
Compound 3: middle estimate off by 2.0-fold (0.30 log units), on the low side; the measured number falls inside the stated range.
By their numbers in this assay, from the lowest: compound 1; then compound 3; then compound 2.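

In this assay, among these compounds, the change to 4-fluorophenyl in place of 4-fluorobenzyl on the amide-type nitrogen gives a 3.5-fold higher number from compound 1 to compound 3 (0.55 log units; beyond the scatter) and is the first single-place step. It shows that this position responds to the change, with 4-fluorobenzyl carrying the lower number of the pair. No data at hand explain this step.

The compounds shown leave open whether a longer chain on this nitrogen, such as 2-(4-fluorophenyl)ethyl, would lower the number further. They also leave open what plain benzyl without the fluorine would give.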